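The source may report more compounds than this note shows. Statements on the series, on what has been measured and on what is new or still open speak of the compounds shown alone.

Of the compounds shown here, two of a shared core have been measured in an assay on HEK293 cells for inhibition of acid ceramidase (Homo sapiens), read by fluorescence, with stated times of 10 min and 3 h; a lower number here means a stronger inhibitor, a higher number a weaker inhibitor. Compound 1, `CN1CCC(c2ccc3c(c2)oc(=O)n3C(=O)NCCOCc2ccccc2)CC1`, gives 215 nM in this assay. Compound 2, `CN1CCC(c2ccc3c(c2)oc(=O)n3C(=O)NCCCCc2ccccc2)CC1=O`, gives 105 nM in this assay. On these two numbers compound 2 stands lowest, and the gap to its nearest neighbour, compound 1, lies beyond the usual scatter of repeated measurements, so compound 2 is the stronger inhibitor of the pair.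

Compound 3, `CC(=O)N1CCC(c2ccc3c(c2)oc(=O)n3C(=O)NCCCCc2ccccc2)CC1`, has not yet been measured in this assay. It differs from compound 2 in one place: 1-acetylpiperidin-4-yl in place of 1-methyl-2-oxopiperidin-4-yl on an aromatic carbon The group that leaves and the group that enters are both neutral, each carries a single hydrogen-bond acceptor and no donor, and each holds one six-membered non-aromatic ring with one hetero atom, so the change is small in count. Within the data shown here, no step between two measured compounds covers this change, and nothing in the two numbers tells its direction.

Compound 3 is therefore expected to stay close to compound 2, with a step of a 1.4-fold higher number from compound 2 to compound 3 (0.15 log units; within the scatter) that is estimated not to pass beyond the scatter. For compound 3 the estimate in this assay is 150 nM, with a range from 60 nM to 400 nM.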

Compound 3, half-maximal inhibitory concentration in the acid ceramidase assay: 64 nM
Compound 3: middle estimate off by 2.3-fold (0.37 log units), on the high side; the range from low to high includes it.
By their numbers in the acid ceramidase assay, from the lowest: compounds 3 and 2 (each within the scatter of the next); then compound 1.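

In the acid ceramidase assay, putting 1-acetylpiperidin-4-yl in place of 1-methyl-2-oxopiperidin-4-yl on the aromatic carbon gives a 1.6-fold lower number from compound 2 to compound 3 (0.22 log units; within the scatter), so this pair, which differs in this one place only, cannot be told apart as inhibitors. The earlier numbers gave no view of this position, and a second read-out now adds what inhibition alone does not show: in a physicochemical assay for solubility, read by HPLC, in phosphate buffer, measured as kinetic solubility, with a stated time of 1 h, at pH 7.4, tested at 250 uM (on this read-out lower numbers stand for lower solubility and higher numbers for higher solubility), compound 2 gives 20000 nM. In the physicochemical assay, compound 3 gives < 1000 nM, which is a limit of the assay and not a number.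

From the compounds shown here alone, how far the solubility of compound 3 lies from that of compound 2 stays open, because only a limit is available for compound 3: the limit of < 1000 nM in the physicochemical assay, at which 1 of the 2 values shown sits. Whether a free amine or a carboxylic acid on the piperidine ring at this position would keep inhibition in the acid ceramidase assay while giving a measurable number in the physicochemical assay is also something these compounds do not tell.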